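An Inert tert-Butyl Triazole Gives Way to Difluorophenyl

This account rests on a few compounds, and the source may have more. Where it says the series, first, only, none or still open, it means among the compounds named here.

Compound 3 `CC(C)(C)c1cn(Cc2cc(=O)oc3cc(O)ccc23)nn1` carries a tert-butyl group on the five-membered ring. In a functional assay on HepG2 cells (Homo sapiens) for inhibition, read by MTT assay, with a stated time of 72 h (a higher number here means a weaker inhibitor, a lower number a stronger inhibitor), compound 3 returns only a limit of the assay, > 100000 nM. Compound 1 `O=c1cc(Cn2cc(C3CC3)nn2)c2ccc(O)cc2o1`, with cyclopropyl in that place, also gives in this assay only a limit, > 100000 nM. Compound 2 `O=c1cc(Cn2cc(CCCCl)nn2)c2ccc(O)cc2o1`, with a 3-chloropropyl chain there, likewise shows in this assay only a limit, > 100000 nM. The three steps a step that the two limits leave unreadable from compound 1 to compound 2, a step that the two limits leave unreadable from compound 1 to compound 3 and a step that the two limits leave unreadable from compound 2 to compound 3 therefore have no readable size, since every value sits at the same limit (the limit of > 100000 nM in this assay, at which 3 of the 3 values shown sit).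

Compound 4 `O=c1cc(Cn2cc(-c3cc(F)cc(F)c3)nn2)c2ccc(O)cc2o1` differs from compound 3 by 3,5-difluorophenyl in place of tert-butyl on an aromatic carbon. Going by the values given here, no measured step bears a readable size on this change, so the data offer neither a direction nor a magnitude for this assay. Compound 4 is accordingly expected to remain near the limit, with an estimate of 80000 nM and a range from 15000 nM to 300000 nM. This implies an expected step of an at least 1.2-fold lower number from compound 3 to compound 4 (0.09 log units; that floor lies within the scatter), which cannot be set against a limit with confidence.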

Compound 4, half-maximal inhibitory concentration: 38900 nM
Compound 4: middle estimate off by 2.1-fold (0.31 log units), on the high side; measured number inside the range.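

Going by these compounds alone, the change at this position gives the first readable steps in this assay: an at least 2.5-fold lower number from compound 3 to compound 4 (0.41 log units; beyond the scatter), together with an at least 2.5-fold lower number from compound 2 to compound 4 (0.41 log units; beyond the scatter) and an at least 2.5-fold lower number from compound 1 to compound 4 (0.41 log units; beyond the scatter). Each of these steps starts from a limit of the assay, so each gives a floor and not a full size, though all three floors lie beyond the usual scatter. Among the four compounds, 3,5-difluorophenyl is the only group with a six-membered aromatic ring and the only one that brings the read-out off the ceiling, while cyclopropyl, 3-chloropropyl and tert-butyl stay there: the limit of > 100000 nM in this assay, at which 3 of the 4 values shown sit.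

The compounds shown leave open whether the step follows the ring itself or its two fluorine atoms, and how a plain phenyl would read at this place. Also open, from the compounds shown here alone, is how a phenyl carrying an amine or a carboxylic acid would read there.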